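The source may hold more compounds than are shown below. What is called first, only, known or untested is meant among the compounds shown, and "the series" means these compounds.

Measured compounds in an assay for inhibition of NAD-dependent protein deacylase sirtuin-6 (Homo sapiens), read by HPLC, with stated times of 15 min and 1 h, tested at 333 uM; a higher number here means more inhibition at the concentration tested (going by the name of the read-out), a lower number less inhibition:
compound 1 `CCCCCCNC(=O)CCCSC[C@H](NC(=O)OCc1ccccc1)C(=O)Nc1ccccc1`: "not active" (no number reported)
compound 2 `CCCCCCCCCCCCCNC(=O)CCCSC[C@H](NC(=O)OCc1ccccc1)C(=O)Nc1ccccc1`: 31%
compound 3 `CCCCNC(=O)CCCSC[C@H](NC(=O)OCc1ccccc1)C(=O)Nc1ccccc1`: 26%

Compound 1 stands without a number: in this assay compound 1 is reported as "not active" (no number reported) and no percentage is given, so it cannot be placed against the numbers of compound 2 and compound 3. The step from compound 1 to compound 4 `CCNC(=O)CCCSC[C@H](NC(=O)OCc1ccccc1)C(=O)Nc1ccccc1` is hydrogen in place of butyl on a saturated chain carbon, two bonds along the chain from an amide-type nitrogen. Going by the values given here, the only measured step of a similar kind, a shortening of the same amide chain, is a number 5 percentage points lower from compound 2 to compound 3 (within the scatter). That step lay within the scatter, so shortening the chain there changed nothing to speak of; yet compound 1 with its hexyl chain gave no reported activity, so the three measured compounds do not follow the chain in any plain way, compound 1 going against a simple trend from compound 2 to compound 3. Among the compounds with values here, no measured step carries over directly to compound 4; the expectation rests mainly on compound 1 having given "not active" (no number reported). Compound 4 is therefore expected to give about 12%, within 0% to 30%, and may well be reported without a number.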

Compound 4, a percentage reported as inhibition, at one concentration (the size of the read-out at that concentration, not a potency): 15%
Beside the measured number, compound 4's estimate is 3 percentage points below it, within the range that was stated.
By their numbers in this assay, from the lowest: compound 4; then compounds 3 and 2 (each within the scatter of the next).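

Shortening the chain on a saturated chain carbon, two bonds along the chain from an amide-type nitrogen, now gives a loss in this assay beyond the scatter: a number 11 percentage points lower from compound 3 to compound 4 (beyond the scatter) and a number 16 percentage points lower from compound 2 to compound 4 (beyond the scatter), whereas the earlier step, a number 5 percentage points lower from compound 2 to compound 3 (within the scatter), did not. A fall with shorter chain fits compound 2, compound 3 and compound 4 only, and compound 1 goes against it: with its hexyl chain, compound 1 is reported as "not active" (no number reported), so steps to compound 1 cannot be read. Nothing available bears on the reason for this loss.

Open, from the compounds shown here alone, is whether a methyl chain would lower the number further, and whether a carboxylic acid or an amine carried on the chain would restore it. Also open is why compound 1 stands apart from compound 3 and compound 4.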